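Replacing the dimethylcarbamoyl amide of compound 3 with acetyl

A few compounds are considered here, and "the series" means these few. Any claim that something is new, unique, unknown or untested is made for them only; others in the source may bear on it.

Compound 1 `O=C(CCCCCCc1ccccc1)c1ncc(-c2ccncn2)o1` gives 2.3 nM in an assay (Rattus norvegicus) for inhibition of Fatty-acid amide hydrolase 1 (Homo sapiens); a lower number here means a stronger inhibitor, a higher number a weaker inhibitor. Compound 2 `CNC(=O)c1cnc(C(=O)CCCCCCc2ccccc2)o1` gives 7 nM, and compound 3 `CN(C)C(=O)c1cnc(C(=O)CCCCCCc2ccccc2)o1` gives 2 nM. Compound 3 holds the lowest number of the three, though its gap to compound 1 sits within the scatter, so the two cannot be ranked; only compound 2 stands apart, with a 3.5-fold lower number from compound 2 to compound 3 (0.54 log units; beyond the scatter). Compound 4 `CC(=O)c1cnc(C(=O)CCCCCCc2ccccc2)o1` carries methyl in place of dimethylamino on a carbonyl carbon, so the amide of compound 3 becomes a ketone. Among the measured compounds shown here, no measured step tests this exact change. For the measured compounds named here, the steps that bear on it are a 1.2-fold lower number from compound 1 to compound 3 (0.06 log units; within the scatter) and a 3.0-fold higher number from compound 1 to compound 2 (0.48 log units; beyond the scatter), which together show that three quite different groups at this position all keep the number within a narrow band, and a 3.5-fold lower number from compound 2 to compound 3 (0.54 log units; beyond the scatter), the largest move seen. An acetyl group falls in the same range of variation, so a step in this assay no larger than those is expected, most likely a small rise in the number. The expected step is a 2.0-fold higher number from compound 3 to compound 4 (0.30 log units; within the scatter). Compound 4 is therefore estimated at 4 nM, within 1.5 nM to 12 nM.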

Compound 4, inhibition constant: 2 nM
Beside the measured number, compound 4's estimate is 2.0-fold (0.30 log units) above it; the measured number falls inside the stated range.
By their numbers in this assay, from the lowest: compounds 3, 4 and 1 (each within the scatter of the next); then compound 2.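

In this assay, methyl in place of dimethylamino on a carbonyl carbon gives no change at the digits printed from compound 3 to compound 4 (within the scatter), so the nitrogen of the dimethylcarbamoyl group is not needed at this position, and a 1.2-fold lower number from compound 1 to compound 4 (0.06 log units; within the scatter) places acetyl with pyrimidin-4-yl as well. Methylcarbamoyl in compound 2 is now the only one of the four groups set apart, with a 3.5-fold lower number from compound 2 to compound 4 (0.54 log units; beyond the scatter), a step the same size as the one to compound 3, and it is also the only group of the four that carries an amide hydrogen. No data shown explain why this group alone stands apart.

On these data alone, whether the narrow band extends to a carboxylic acid, an unsubstituted carboxamide or a longer ketone such as propanoyl at this position stays open. Also open, as far as these compounds go, is whether it holds with a shorter or longer chain on the shared core.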